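The compounds below may be only part of what the source reports. "The series", "measured", "known", "first", "only" and "open" are said of these compounds alone.

Measured compounds in the series:

Compound 1, `O=c1cc(/C=N\Nc2ccc([N+](=O)[O-])cc2)c2ccc(OCc3ccccc3)cc2o1`: 9510 nM
Compound 2, `O=c1cc(/C=N\Nc2ccccc2)c2ccc(OCc3ccccc3)cc2o1`: 13200 nM
Compound 3, `O=c1cc(/C=N\Nc2ccc([N+](=O)[O-])cc2)c2c(OCc3ccccc3)cc(OCc3ccccc3)cc2o1`: 15500 nM

All three numbers come from a functional assay, read by spectrophotometry, with a stated time of 3 min; on this read-out lower numbers stand for stronger inhibition and higher numbers for weaker inhibition. Compound 1 and compound 2 share one core and differ by hydrogen in place of nitro on an aromatic carbon. The step that this change made is a 1.4-fold higher number from compound 1 to compound 2 (0.14 log units; within the scatter), so the two values cannot be told apart. Compound 3 carries a second benzyloxy group on the core; the difference between the two cores is benzyloxy in place of hydrogen on an aromatic carbon, and the step that goes with it is a 1.6-fold higher number from compound 1 to compound 3 (0.21 log units; within the scatter). Compound 3 sits at the highest of the three numbers, but its gaps to compound 2 and to compound 1 are both small, and no ordering among the three is supported.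

Compound 4, `O=c1cc(/C=N\Nc2ccccc2)c2c(OCc3ccccc3)cc(OCc3ccccc3)cc2o1`, has not been measured in this assay. It stands to compound 3 as compound 2 stands to compound 1: the difference is hydrogen in place of nitro on an aromatic carbon. The place lines of the two changes read the same word for word, so this is the same change, carried from the core of compound 1 onto the core of compound 3. Within the data shown here, with only one measured instance of the change, the expectation for compound 4 rests on that step: in this assay a step of about a 1.4-fold higher number from compound 3 to compound 4 (0.13 log units; within the scatter) is expected from compound 3 to compound 4, mirroring the earlier step. Compound 4 is accordingly estimated at 21000 nM, with a likely range from 9000 nM to 50000 nM.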

Compound 4, half-maximal inhibitory concentration: 40100 nM
Estimate against measurement, compound 4: 1.9-fold (0.28 log units) below; the measured number falls inside the stated range.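

Hydrogen in place of nitro on the core with the second benzyloxy group gives a 2.6-fold higher number from compound 3 to compound 4 (0.41 log units; beyond the scatter) in this assay, and this step cannot be told apart from the earlier one on the other core: the same change on two cores in this assay, a 1.4-fold higher number (0.14 log units; within the scatter) from compound 1 to compound 2 and a 2.6-fold higher number (0.41 log units; beyond the scatter) from compound 3 to compound 4, 1.9-fold (0.27 log units) apart, within the scatter of two such steps

Benzyloxy in place of hydrogen, read on the compounds without nitro, gives a 3.0-fold higher number from compound 2 to compound 4 (0.48 log units; beyond the scatter), and this step likewise stays within reach of its earlier counterpart: the same change on two cores in this assay, a 1.6-fold higher number (0.21 log units; within the scatter) from compound 1 to compound 3 and a 3.0-fold higher number (0.48 log units; beyond the scatter) from compound 2 to compound 4, 1.9-fold (0.27 log units) apart, within the scatter of two such steps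

Both changes therefore carry from one core to the other as far as these data can tell, but that does not show that the steps are equal, or that either change truly counts for more on the second core, since the two comparisons rest on the same four values and form a single closed set.

Going by these compounds, it remains open whether other groups in place of nitro on that aromatic ring, such as an amine or a carboxylic acid, would follow the same steps. On these data alone, it is equally open whether a group other than benzyloxy on the core, such as methoxy, would give a step of similar size.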